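The source may report more compounds than this note shows. Statements on the series, on what has been measured and on what is new or still open speak of the compounds shown alone.

Of the compounds shown here, three have been measured so far. Compound 1 `NS(=O)(=O)c1sc(Cl)cc1-c1csc(-c2ccccc2COc2ccc(Cl)cc2)n1` gives 76.4% in a functional assay on the whole organism (strain Wistar albino) for inhibition, with Rattus norvegicus as the target, read by paw edema, at a dose of 10 mg/kg by the oral route; a lower number here means less inhibition, a higher number more inhibition at the dose given (going by the name of the read-out). Compound 2 `Cc1ccccc1OCc1ccccc1-c1nc(COc2ccc(Cl)cc2)cs1` gives 65.1% in this assay, and compound 3 `Cc1ccc(OCc2ccccc2-c2nc(COc3ccc(Cl)cc3)cs2)cc1` gives 68.7%. Compound 3 therefore stands second highest of the three numbers; its nearest neighbour is compound 2, and the difference between them is within the scatter, while the gap to compound 1 is also within the scatter, so no order can be read among the three.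

Among the measured compounds shown here, the one step that can be followed between measured compounds is a number 3.6 percentage points higher from compound 2 to compound 3 (within the scatter), which moves the methyl group within its ring and changes nothing beyond the scatter.

Compound 4 `Clc1ccc(OCc2csc(-c3ccccc3COc3ccc(Cl)cc3)n2)cc1` differs from compound 3 by chloro in place of methyl on an aromatic carbon. For the measured compounds named here, no measured pair shows a chloro replacing a methyl, so the only step that bears on it, the one from compound 2 to compound 3, speaks for a small effect of changes on this ring, and nothing in the data argues for a move in either direction. Compound 4 is therefore expected to show a step of no change at the digits printed from compound 3 to compound 4 (within the scatter) in this assay, essentially none beyond the scatter. The estimate for compound 4 is 68.7%, with a range from 58% to 79%.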

Compound 4, a percentage reported as inhibition, in the whole organism at one dose (the size of the read-out at that dose, not a potency): 76.4%
Compound 4: the middle estimate sits 7.7 percentage points below what was measured, within the range that was stated.
By their numbers in this assay, from the lowest: compounds 2, 3, 1 and 4 (each within the scatter of the next, the first and the last beyond it).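

In this assay, putting chloro in place of methyl on this aromatic carbon, para to a large group, gives a number 7.7 percentage points higher from compound 3 to compound 4 (within the scatter), so this swap alone cannot be told apart from repeat scatter. Among the compounds shown here, the wider comparison, with 4-chlorophenyl in place of 2-methylphenyl, gives a number 11.3 percentage points higher from compound 2 to compound 4 (beyond the scatter), the first step to pass beyond the scatter, though it is modest and spans both the change of substituent and its place on the ring. With (4-chlorophenoxy)methyl in place of 5-chloro-2-sulfamoylthiophen-3-yl there is no change at the digits printed from compound 1 to compound 4 (within the scatter), so in this pair the sulfamoyl-bearing thiophene is not required for this level of inhibition at the dose given, and nothing at hand accounts for any of these steps.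

On these data alone, only methyl and chloro are compared at this position with the rest of the molecule held constant, so what a methoxy, an amine or a carboxylic acid would do there remains open. All readings come from a single oral dose, which leaves open whether compound 1 and compound 4 would still match at other doses.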